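Aryl variation on the shared core: compound 3 estimate

The source may hold more compounds than are shown below. What is called first, only, known or untested is meant among the compounds shown, and "the series" means these compounds.

Measured so far in a functional assay on ACHN cells (Homo sapiens) for inhibition, read by sulforhodamine B assay, with a stated time of 48 h, tested at 10 uM; a lower number here means less inhibition, a higher number more inhibition at the concentration tested (going by the name of the read-out):
compound 1, `c1ccc2c(-c3cn4ccnc4c(-c4ccc5ncn(C6CCCCC6)c5c4)n3)cccc2c1`, gives 6.49%
compound 2, `Brc1ccc(-c2cn3ccnc3c(-c3ccc4ncn(C5CCCCC5)c4c3)n2)cc1`, gives 21.4%
compound 3, `FC(F)(F)c1cccc(-c2cn3ccnc3c(-c3ccc4ncn(C5CCCCC5)c4c3)n2)c1`, awaits measurement

Compound 2 holds the higher of the two numbers in this assay; its nearest neighbour is compound 1, the gap being a number 14.9 percentage points higher from compound 1 to compound 2 (beyond the scatter). Compound 3 differs from compound 2 in one place: 3-(trifluoromethyl)phenyl in place of 4-bromophenyl on an aromatic carbon. Going by the values given here, no measured step shows the same exchange. Among the compounds with values here, the only step known at this aromatic carbon, a number 14.9 percentage points higher from compound 1 to compound 2 (beyond the scatter), shows the read-out does move when the group there changes, but it gives no direction for the present exchange. With a single step as guide, the expectation for compound 3 is a step of a number 3.4 percentage points lower from compound 2 to compound 3 (within the scatter), that is, little beyond the scatter in either direction. Compound 3 is therefore estimated at 18%, within a range of 4% to 40%.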

Compound 3, a percentage reported as inhibition, at one concentration (the size of the read-out at that concentration, not a potency): 0.3%
Beside the measured number, compound 3's estimate is 17.7 percentage points above it; measured number outside the range, below it.
By their numbers in this assay, from the lowest: compounds 3 and 1 (each within the scatter of the next); then compound 2.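

In this assay, the step of a number 21.1 percentage points lower from compound 2 to compound 3 (beyond the scatter) shows that a substituted phenyl at this aromatic carbon does not by itself secure the read-out of compound 2, since 3-(trifluoromethyl)phenyl does not keep what 4-bromophenyl gives. The step of a number 6.2 percentage points lower from compound 1 to compound 3 (within the scatter) then places two quite different groups, naphthalen-1-yl and 3-(trifluoromethyl)phenyl, within the scatter of each other, leaving compound 2 alone beyond the scatter of both. Nothing measured here bears on why the read-out moves at this carbon.

This exchange alters both the substituent and its place on the phenyl ring, so the two contributions cannot be separated with these compounds. Also open, on these data alone, is how a phenyl ring carrying an amine or a carboxylic acid would read at this carbon.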